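Butyl in place of bromo on a weakly active alkynyl uracil

A few compounds are considered here, and "the series" means these few. Any claim that something is new, unique, unknown or untested is made for them only; others in the source may bear on it.

Going by the values given here, compound 1 `O=C1c2ccccc2C(=O)N1C/C=C\Cn1cc(C#Cc2ccc(Br)cc2)c(=O)[nH]c1=O` is the single measured compound for which a number is given in a functional assay on L1210 cells (Mus musculus) for antiproliferative activity, read by MTT assay, with a stated time of 2 days; on this read-out higher numbers stand for weaker inhibition and lower numbers for stronger inhibition. In this assay compound 1 gives 448000 nM, which marks it as a weak inhibitor of cell growth. Compound 2 `CCCCCCCCC#Cc1cn(C/C=C/CN2C(=O)c3ccccc3C2=O)c(=O)[nH]c1=O` shares the core and the alkyne but carries a nonyl chain instead of the aryl group. In this assay compound 2 gives only a limit of > 250000 nM and no number, so that the two compounds cannot be ordered against each other; the limit of > 250000 nM in this assay, at which 1 of the 2 values shown sits, shows how the values shown sit.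

Compound 3 `CCCCc1ccc(C#Cc2cn(C/C=C\CN3C(=O)c4ccccc4C3=O)c(=O)[nH]c2=O)cc1` differs from compound 1 by the change (butyl in place of bromo on an aromatic carbon), butyl in place of bromo on an aromatic carbon. No measured step is shown for this kind of change, so nothing beyond the scatter is expected from it. For compound 3 the estimate in this assay is 400000 nM, with a range from 150000 nM to 1000000 nM, meaning an expected step of a 1.1-fold lower number from compound 1 to compound 3 (0.05 log units; within the scatter).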

Compound 3, half-maximal inhibitory concentration: 31000 nM
Beside the measured number, compound 3's estimate is 13-fold (1.11 log units) above it; the whole stated range lies above it.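

Replacing bromo with butyl gives a 14-fold lower number from compound 1 to compound 3 (1.16 log units; beyond the scatter) in this assay. Going by these compounds alone, the earlier compounds offered no pair differing in one place, so this is the first sign that the group on this aromatic carbon, para to a large group, can shift the antiproliferative read-out by more than the usual scatter. The result rests on a single pair, and nothing measured here accounts for the size of the step.

The compounds shown leave open whether a shorter chain such as methyl, a longer chain such as hexyl, or an amine at the same place would lower the number further or raise it again. Also open, from the compounds shown here alone, is whether butyl in place of bromo would give a step of similar size on any compound other than compound 1.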